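Swapping a methoxybenzyl arm for a chlorophenyl ring

The source may report more compounds than this note shows. Statements on the series, on what has been measured and on what is new or still open speak of the compounds shown alone.

Measured so far in a functional assay on CCRF-CEM cells (Homo sapiens) for inhibition, read by cell counting, with a stated time of 3 days; on this read-out lower numbers stand for stronger inhibition and higher numbers for weaker inhibition:
compound 1 `C=C(Br)C(=O)Nc1cccc(-c2cn3nc(-c4ccc(OCC)cc4)sc3n2)c1` gives 1400 nM
compound 2 `C=C(Br)C(=O)Nc1cccc(-c2cn3nc(Cc4cccc(OC)c4)sc3n2)c1` gives 3100 nM
compound 3 `C=C(Br)C(=O)Nc1cccc(-c2cn3nc(Cc4ccc(OC)cc4)sc3n2)c1` gives 2300 nM

Compound 3 holds the second highest of the three numbers; the gaps to compound 2, a 1.3-fold lower number from compound 2 to compound 3 (0.13 log units; within the scatter), and to compound 1, a 1.6-fold higher number from compound 1 to compound 3 (0.22 log units; within the scatter), both sit within the scatter, so no order among them can be claimed. Compound 4 `C=C(Br)C(=O)Nc1cccc(-c2cn3nc(-c4ccc(Cl)cc4)sc3n2)c1` differs from compound 3 in one place: 4-chlorophenyl in place of 4-methoxybenzyl on an aromatic carbon. Compound 4 thus carries a phenyl ring on the core like compound 1, whereas compound 2 and compound 3 carry benzyl groups. The bearing steps are a 2.2-fold higher number from compound 1 to compound 2 (0.35 log units; beyond the scatter) and a 1.6-fold higher number from compound 1 to compound 3 (0.22 log units; within the scatter). Compound 4 is therefore expected to land near compound 1, at an estimated 1500 nM with a range of 600 nM to 4000 nM. That expectation amounts to a 1.5-fold lower number from compound 3 to compound 4 (0.19 log units; within the scatter), a small downward step.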

Compound 4, half-maximal inhibitory concentration: 3200 nM
Compound 4: middle estimate off by 2.1-fold (0.33 log units), on the low side; low and high end bracket the measured number.
By their numbers in this assay, from the lowest: compounds 1, 3, 2 and 4 (each within the scatter of the next, the first and the last beyond it).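

Carrying a phenyl ring on the core does not by itself set a compound apart from the benzyl compounds: the steps of a 1.4-fold higher number from compound 3 to compound 4 (0.14 log units; within the scatter) and a 1.0-fold higher number from compound 2 to compound 4 (0.01 log units; within the scatter) both stay within the scatter. The group on that phenyl ring can shift the number, as chloro in place of ethoxy gives a 2.3-fold higher number from compound 1 to compound 4 (0.36 log units; beyond the scatter) and is a modest step beyond the scatter. No evidence at hand bears on the reason for this step. The compounds shown leave open what a plain phenyl ring, or an amine in place of the chloro, would give.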